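Pyrimidinyl prolinamide series: amide substituent swap

The source may hold more compounds than are shown below. What is called first, only, known or untested is meant among the compounds shown, and "the series" means these compounds.

Measured so far:
Compound 1 `Cc1cccc(Oc2ccnc(N3CCC[C@H]3C(=O)NCCCn3ccnc3)n2)c1` — 2%
Compound 2 `Clc1ccc2sc(CN3CCN(c4ncnc5c4CN(Cc4ccccc4)CC5)CC3)cc2c1` — 6%

Both measured compounds were tested in an assay on isolated protein for inhibition of tyrosine-protein kinase Fes/Fps (Homo sapiens), read by HTRF, tested at 10 uM; a higher number here means more inhibition at the concentration tested (going by the name of the read-out), a lower number less inhibition. Compound 1 gives 2% and compound 2 gives 6%; these two values lie within the scatter of each other, so neither can be set above the other. Compound 1 therefore stands simply among two low, indistinguishable numbers.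

Compound 3 `COC(=O)C(CO)NC(=O)[C@@H]1CCCN1c1nccc(Oc2cccc(C)c2)n1` shares its core with compound 1 and differs from it in one place: 2-hydroxy-1-(methoxycarbonyl)ethyl in place of 3-(1H-imidazol-1-yl)propyl on an amide-type nitrogen. Going by the values given here, no comparable step between two measured compounds is available in this set, so nothing measured speaks for a change beyond the scatter in either direction. The step from compound 1 to compound 3 is expected to be a number 1 percentage points higher from compound 1 to compound 3 (within the scatter), that is, none beyond the scatter. Compound 3 is therefore estimated at 3%, within a range from -8% to 15%.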

Compound 3, a percentage reported as inhibition, at one concentration (the size of the read-out at that concentration, not a potency): 0%
Estimate against measurement, compound 3: 3 percentage points above; the range from low to high includes it.
By their numbers in this assay, from the lowest: compounds 3, 1 and 2 (each within the scatter of the next).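

On the amide-type nitrogen of the shared core, 2-hydroxy-1-(methoxycarbonyl)ethyl in place of 3-(1H-imidazol-1-yl)propyl gives, in this assay, a number 2 percentage points lower from compound 1 to compound 3 (within the scatter). This first step at this position shows that a substituent with no ring can stand in for one carrying a five-membered aromatic ring without a change that can be told from the scatter, and the numbers stay low on both sides of the step. Nothing at hand explains this result.

The compounds shown leave open whether any substituent on this nitrogen can lift the number clear of the scatter. A carboxylic acid, a simple amine or a longer chain ending in a phenyl ring at this place would each bear on that question.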